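Cytotoxicity notes on the bicyclic thymidine sulfonate series

This account rests on a few compounds, and the source may have more. Where it says the series, first, only, none or still open, it means among the compounds named here.

Measured so far:
compound 1 `Cc1cn([C@@H]2O[C@H](CO[Si](C)(C)C(C)(C)C)[C@@]3(OS(=O)(=O)C=C3NCCC(N)=O)[C@H]2O[Si](C)(C)C(C)(C)C)c(=O)n(C)c1=O` — 20000 nM
compound 2 `Cc1cn([C@@H]2O[C@H](CO[Si](C)(C)C(C)(C)C)[C@@]3(OS(=O)(=O)C=C3NCC(=O)OCc3ccccc3)[C@H]2O[Si](C)(C)C(C)(C)C)c(=O)n(C)c1=O` — 250000 nM

Going by the values given here, in a functional assay on MT4 cells (Homo sapiens) (on this read-out higher numbers stand for lower toxicity in this test and lower numbers for higher toxicity in this test), compound 1 gives 20000 nM, the lowest of the two numbers; its nearest neighbour is compound 2 at 250000 nM, and the change a 13-fold higher number from compound 1 to compound 2 (1.10 log units; beyond the scatter) is the only step so far.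

The next compound, compound 3 `Cc1cn([C@@H]2O[C@H](CO[Si](C)(C)C(C)(C)C)[C@@]3(OS(=O)(=O)C=C3NCC(=O)O)[C@H]2O[Si](C)(C)C(C)(C)C)c(=O)n(C)c1=O`, differs from compound 1 by carboxy in place of carbamoylmethyl on a saturated chain carbon bound to an amine nitrogen. This is not the same change as from compound 1 to compound 2: there the benzyloxycarbonyl entered at the same place, and the number rose strongly. Among the compounds with values here, the only bearing that step has here is that altering the substituent on this saturated chain carbon bound to the amine nitrogen can move this assay by a large amount. Nothing measured shows what a carboxy does at this position, so an upward move is plausible but cannot be sized from the data; the expectation is set near compound 1 with a wide range, leaning higher. Compound 3 is therefore estimated at 40000 nM (range 12000 nM to 160000 nM), an expected step of a 2.0-fold higher number from compound 1 to compound 3 (0.30 log units; within the scatter).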

Compound 3, half-maximal cytotoxic concentration: 30000 nM
The estimate for compound 3 lay 1.3-fold (0.12 log units) above the measured number; measured number inside the range.
By their numbers in this assay, from the lowest: compounds 1 and 3 (each within the scatter of the next); then compound 2.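

In this assay the replacement of carbamoylmethyl by carboxy on the saturated chain carbon bound to an amine nitrogen gives a 1.5-fold higher number from compound 1 to compound 3 (0.18 log units; within the scatter), so this read-out does not separate these two groups at this place. The step to hydrogen in place of benzyl on an oxygen next to a carbonyl group gives an 8.3-fold lower number from compound 2 to compound 3 (0.92 log units; beyond the scatter), so among the three compounds the high number stands only with the benzyl ester of compound 2, and no compound shown goes against this. No measurement at hand gives a reason for either step.

Still open, from the compounds shown here alone, is whether a methyl ester or an ethyl ester in place of the benzyl ester would keep the number of compound 2 or stand with compound 3, which would show whether the ester alone or the benzyl group carries the step. Also open is what 2-carboxyethyl would give on the amine nitrogen, since the groups of compound 1 and compound 3 differ in both chain and end group, and a simple amine at the chain end remains untested among the compounds shown here.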